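Solubility Outlook for a Monochlorophenyl Amide

A few compounds are considered here, and "the series" means these few. Any claim that something is new, unique, unknown or untested is made for them only; others in the source may bear on it.

Compound 2 `O=C(Nc1cccc(C(=O)C(=O)c2ccccn2)c1)c1ccc(F)c(F)c1` is the less soluble of the two measured compounds: in a physicochemical assay for solubility, at pH 4.0 (on this read-out higher numbers stand for higher solubility and lower numbers for lower solubility), compound 2 gives 0.7 ug/mL, while compound 1 `O=C(C(=O)c1ccccn1)c1cccc(NC(=O)c2ccc(Cl)cc2Cl)c1` gives 3.3 ug/mL. Among the measured compounds shown here, the one measured step, a 4.7-fold lower number from compound 1 to compound 2 (0.67 log units; beyond the scatter), replaced the 2,4-dichlorophenyl with the 3,4-difluorophenyl on a carbonyl carbon. Compound 3 `O=C(Nc1cccc(C(=O)C(=O)c2ccccn2)c1)c1cccc(Cl)c1` is not yet measured; it differs from compound 2 by 3-chlorophenyl in place of 3,4-difluorophenyl on a carbonyl carbon. The step from compound 1 to compound 2 bears on this change in a loose way, since it also exchanges halogens on the same ring and showed a modest drop when chlorines gave way to fluorines. Returning a single chlorine is therefore expected to move this assay upward by a modest amount, a 2.1-fold higher number from compound 2 to compound 3 (0.33 log units; beyond the scatter). For compound 3 the estimate in this assay is 1.5 ug/mL, with a range from 0.5 ug/mL to 5 ug/mL.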

Compound 3, solubility: 3.1 ug/mL
Compound 3: middle estimate off by 2.1-fold (0.32 log units), on the low side; measured number inside the range.
By their numbers in this assay, from the lowest: compound 2; then compounds 3 and 1 (each within the scatter of the next).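

In this assay the change to 3-chlorophenyl on this carbonyl carbon gives a 4.4-fold higher number from compound 2 to compound 3 (0.65 log units; beyond the scatter) and so shows that the low number of compound 2 is not shared by every halogen-bearing ring tried at this position. The comparison with the 2,4-dichlorophenyl gives a 1.1-fold lower number from compound 1 to compound 3 (0.03 log units; within the scatter) and leaves compound 1 and compound 3 indistinguishable, so among these three compounds only compound 2, with its 3,4-difluorophenyl, stands apart. Nothing measured here explains this difference.

On these data alone, it remains open whether the 3,4-difluorophenyl result reflects the fluorines themselves or their placement on the ring, as no ring here carries a single fluorine. It is also unknown whether an amine or a carboxylic acid on this ring would take the number beyond those of compound 1 and compound 3.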